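A few compounds are considered here, and "the series" means these few. Any claim that something is new, unique, unknown or untested is made for them only; others in the source may bear on it.

Compound 1 `C=CC1=C(C(=O)NCCC)C(c2ccc(Cl)c(Cl)c2)OC1` and compound 2 `C=CC1=C(C(=O)NCc2ccccc2F)C(c2ccc(F)cc2)OC1` are the two measured compounds. In a functional assay on SW480 cells (Homo sapiens) for cytotoxicity, read by MTT assay, with a stated time of 24 h (a lower number here means a stronger inhibitor, a higher number a weaker inhibitor), compound 1 gives only a limit, > 100000 nM. In this assay compound 2 likewise gives only a limit, > 100000 nM. Compound 2 thus stands at the limit shared by both measured values (the limit of > 100000 nM in this assay, at which 2 of the 2 values shown sit); no numbered value is known for it. Compound 3 `C=CC1=C(C(=O)Nc2cccc(C)c2)C(c2ccc(F)cc2)OC1` carries 3-methylphenyl in place of 2-fluorobenzyl on an amide-type nitrogen. Within the data shown here, no measured step shows what this change does. The step is expected to be a step that the limit leaves unreadable from compound 2 to compound 3, none beyond the scatter, so a limit is again likely. Compound 3 is estimated at 200000 nM, within 50000 nM to 1000000 nM.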

Compound 3, half-maximal inhibitory concentration: > 100000 nM
Compound 3 was reported as a limit; the forecaster's own chance of this, stated with the estimate: 85%; the middle value does not contradict the limit.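

The values of compound 2 and compound 3 are both limits, so no step can be read between them. The compounds shown leave open which change, if any, would give a numbered value in this assay.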